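Working notes: anilino for sulfonyloxy on the shared core

The source may report more compounds than this note shows. Statements on the series, on what has been measured and on what is new or still open speak of the compounds shown alone.

Measured so far in the assay:
- compound 1 `C=C[C@@](C)(/C=C/c1ccc(OS(=O)(=O)C(F)(F)F)cc1)CCC=C(C)C`: > 43400 nM (a limit of the assay)
- compound 2 `C=C[C@](C)(CCCC(C)C)CCc1ccc(O)cc1`: 27500 nM
- compound 3 `C=C[C@@](C)(/C=C/c1ccc(O)c(/C=C(\C)C(=O)OCC)c1)CCC=C(C)C`: > 7500 nM (a limit of the assay)

In a functional assay on NALM-6 cells (Homo sapiens) for cytotoxicity, with a stated time of 72 h (on this read-out lower numbers stand for an effect already at smaller amounts and higher numbers for an effect only at larger amounts of compound), compound 1 gives > 43400 nM, which is a limit of the assay and not a number (the limit of > 43400 nM in this assay, at which 1 of the 3 values shown sits). Compound 2 gives 27500 nM in this assay. Compound 3 gives > 7500 nM in this assay, again a limit (the limit of > 7500 nM in this assay, at which 1 of the 3 values shown sits). Compound 1 thus stands at a limit, and one further of the three values shown is also a limit; none of the three shows an effect at small amounts of compound.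

Compound 4 `C=C[C@@](C)(/C=C/c1ccc(Nc2ccc(Cl)cc2)cc1)CCC=C(C)C` differs from compound 1 by (4-chlorophenyl)amino in place of ((trifluoromethyl)sulfonyl)oxy on an aromatic carbon. For the measured compounds named here, no step between measured compounds covers this change, so its direction rests on the weak values shown alone. The step from compound 1 to compound 4 is expected to be modest, toward an effect at somewhat smaller amounts, an at least 2.8-fold lower number from compound 1 to compound 4 (0.46 log units; beyond the scatter), and may well stay within the scatter. Compound 4 is therefore estimated at 15000 nM in this assay, with a range from 3000 nM to 60000 nM.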

Compound 4, half-maximal effective concentration: > 43400 nM
Compound 4 ended at the assay's limit; the forecaster's own chance of this, stated with the estimate: 40%; middle value at least 2.8-fold (0.46 log units) from the limit.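

Compound 1 and compound 4 both stand at a limit of the assay, and the step between them cannot be read: the limit of > 43400 nM in this assay, at which 2 of the 4 values shown sit.

Going by these compounds, whether (4-chlorophenyl)amino in place of ((trifluoromethyl)sulfonyl)oxy on the shared core changes the effect at all remains open.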